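Swapping Methyl for Bromo on Two Related Cores

The source may hold more compounds than are shown below. What is called first, only, known or untested is meant among the compounds shown, and "the series" means these compounds.

Compound 1 `CCO[C@H]1C[C@@H](c2coc3ccc(C)cc3c2=O)N(c2ccccc2)O1` and compound 2 `Cc1ccc2occ([C@@H]3[C@H]4C(=O)N(c5ccccc5)C(=O)[C@H]4ON3c3ccccc3)c(=O)c2c1` share part of their structure, but the difference between the two cores is not broken down here. In a functional assay on Caco-2 cells (Homo sapiens) for inhibition, read by sulforhodamine B assay, with a stated time of 48 h (a higher number here means a weaker inhibitor, a lower number a stronger inhibitor), compound 1 gives 31000 nM. Compound 2 reaches only the limit of > 60000 nM, so no number is known for it. Compound 3 `O=C1[C@H]2[C@H](ON(c3ccccc3)[C@@H]2c2coc3ccc(Br)cc3c2=O)C(=O)N1c1ccccc1` differs from compound 2 by bromo in place of methyl on an aromatic carbon and in this assay compound 3 gives 20300 nM; this change made an at least 2.9-fold lower number from compound 2 to compound 3 (0.47 log units; beyond the scatter), a step that rests on (the limit of > 60000 nM in this assay, at which 1 of the 3 values shown sits). Compound 4 `CCO[C@H]1C[C@@H](c2coc3ccc(Br)cc3c2=O)N(c2ccccc2)O1` carries the same change on the core of compound 1: bromo in place of methyl on an aromatic carbon. Compound 4 is expected to move by a 2.6-fold lower number from compound 1 to compound 4 (0.41 log units; beyond the scatter) because the measured step of an at least 2.9-fold lower number from compound 2 to compound 3 (0.47 log units; beyond the scatter) went toward a lower number. The estimate for compound 4 is 12000 nM, expected to lie between 4000 nM and 35000 nM.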

Compound 4, half-maximal inhibitory concentration: > 60000 nM
Compound 4: only a limit was reported; the forecaster's own chance of this, stated with the estimate: 5%; at least 5.0-fold (0.69 log units) between middle value and limit.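

In this assay compound 4 gives > 60000 nM, which is a limit and not a number. Bromo in place of methyl on an aromatic carbon gave an at least 1.9-fold higher number from compound 1 to compound 4 (0.28 log units; that floor lies within the scatter), so a gain seen on one core did not carry over to the other: the same change on two cores in this assay, an at least 2.9-fold lower number (0.47 log units; beyond the scatter) from compound 2 to compound 3 and an at least 1.9-fold higher number (0.28 log units; that floor lies within the scatter) from compound 1 to compound 4, at least 5.7-fold (0.75 log units) apart, beyond the scatter of two such steps This does not show how far compound 4 truly moved or why the two cores differ, and both steps rest on a limit: the limit of > 60000 nM in this assay, at which 2 of the 4 values shown sit.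

The compounds shown leave open how chloro, methoxy or an amine on the same aromatic carbon would behave on each core. Among the compounds shown here, with only two pairs, they also leave open whether either direction would hold for further cores.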